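Trimming the side chain of a weak antiproliferative compound

The source may report more compounds than this note shows. Statements on the series, on what has been measured and on what is new or still open speak of the compounds shown alone.

Measured in a functional assay on OVCAR-8 cells (Homo sapiens) for antiproliferative activity; a lower number here means a stronger inhibitor, a higher number a weaker inhibitor:
- compound 1 `Cn1ncc(Cl)c1-c1cc(C(=O)N[C@@H]2CN[C@H](CC(O)CO)C[C@H]2c2ccc(Cl)c(Cl)c2)oc1Cl`: 1610 nM
- compound 2 `Cn1ncc(Cl)c1-c1cc(C(=O)N[C@@H]2CN[C@H](CC(=O)O)C[C@H]2c2ccc(Cl)c(Cl)c2)oc1Cl`: 5120 nM
- compound 3 `Cn1ncc(Cl)c1-c1cc(C(=O)N[C@@H]2CN[C@H](CC(=O)NCC(O)CO)C[C@H]2c2ccc(Cl)c(Cl)c2)oc1Cl`: 5900 nM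

Compound 3 stands at the high end of these numbers, level with compound 2 within the scatter. The data show a 1.2-fold higher number from compound 2 to compound 3 (0.06 log units; within the scatter), and also a 3.7-fold higher number from compound 1 to compound 3 (0.56 log units; beyond the scatter). Compound 4 `CCC[C@@H]1C[C@@H](c2ccc(Cl)c(Cl)c2)[C@H](NC(=O)c2cc(-c3c(Cl)cnn3C)c(Cl)o2)CN1` changes that chain on a saturated chain carbon bound to a saturated ring carbon: ethyl in place of (2,3-dihydroxypropyl)carbamoyl on a saturated chain carbon bound to a saturated ring carbon. Going by the values given here, no measured compound carries a plain alkyl chain there, so this is an extrapolation. The best guide is compound 1, which has no carbonyl in this chain, and the data show a 3.2-fold higher number from compound 1 to compound 2 (0.50 log units; beyond the scatter). A lower number is therefore expected in this assay, by a step probably somewhat larger than these. The expected change is a 7.4-fold lower number from compound 3 to compound 4 (0.87 log units; beyond the scatter). For compound 4 the estimate is 800 nM, with an expected range of 250 nM to 2500 nM.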

Compound 4, half-maximal inhibitory concentration: 1620 nM
Compound 4: the middle estimate sits 2.0-fold (0.31 log units) below what was measured, within the range that was stated.
By their numbers in this assay, from the lowest: compounds 1 and 4 (each within the scatter of the next); then compounds 2 and 3 (each within the scatter of the next).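

In this assay, ethyl gives a lower number than either chain holding a carbonyl (a 3.6-fold lower number from compound 3 to compound 4 (0.56 log units; beyond the scatter); a 3.2-fold lower number from compound 2 to compound 4 (0.50 log units; beyond the scatter)). Ethyl and 1,2-dihydroxyethyl, however, stand level (a 1.0-fold higher number from compound 1 to compound 4 (0.00 log units; within the scatter)), so among these compounds the hydroxy groups of compound 1 neither add to nor take away from the reading, and only the two carbonyl chains stand apart. Nothing at hand explains this difference.

As far as these compounds go, it remains open whether a longer alkyl chain, or an amine on that chain, would stand level with compound 4 or move the number further.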